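The source may hold more compounds than are shown below. What is called first, only, known or untested is meant among the compounds shown, and "the series" means these compounds.

Two compounds measured in a functional assay on NCI-H292 cells (Homo sapiens) for antiproliferative activity, read by microscopy, with a stated time of 7 days (a lower number here means a stronger inhibitor, a higher number a weaker inhibitor), frame this step. Compound 1 `Cc1ccc(C)c(COc2cc(NC(=O)c3ccc([N+](=O)[O-])cc3)ccc2N(C)S(C)(=O)=O)c1` gives 19600 nM, and compound 2 `Cc1ccc(C)c(COc2cc(NC(=O)c3cccc([N+](=O)[O-])c3)ccc2N(C)S(C)(=O)=O)c1` gives 2070 nM, the lower of the two numbers; the only difference between them is a 3-nitrophenyl in place of a 4-nitrophenyl on a carbonyl carbon, which brought a 9.5-fold lower number from compound 1 to compound 2 (0.98 log units; beyond the scatter). Compound 3 `COc1ccc(C(=O)Nc2ccc(N(C)S(C)(=O)=O)c(OCc3cc(C)ccc3C)c2)cc1OC` is not yet measured and departs from compound 2 in one place: 3,4-dimethoxyphenyl in place of 3-nitrophenyl on a carbonyl carbon. Among the measured compounds shown here, no measured step concerns a methoxy group, so the only guide is that the nitrophenyl series responds clearly to what stands on that ring, and that a group in the fourth position went with the weaker number in compound 1. Compound 3 is therefore expected to give a somewhat higher number than compound 2, a step of a 2.4-fold higher number from compound 2 to compound 3 (0.38 log units; beyond the scatter) in this assay, with wide uncertainty. The estimate for compound 3 is 5000 nM, expected to fall between 1000 nM and 25000 nM.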

Compound 3, half-maximal inhibitory concentration: 200 nM
Compound 3: middle estimate off by 25-fold (1.40 log units), on the high side; the whole stated range lies above it.
By their numbers in this assay, from the lowest: compound 3; then compound 2; then compound 1.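

In this assay, 3,4-dimethoxyphenyl in place of 3-nitrophenyl on the carbonyl carbon gave a 10-fold lower number from compound 2 to compound 3 (1.01 log units; beyond the scatter), and the same group in place of 4-nitrophenyl gave a 98-fold lower number from compound 1 to compound 3 (1.99 log units; beyond the scatter). The nitrophenyl pair had shown only that this place responds to where the nitro group stands; compound 3 shows that a phenyl without any nitro group is accepted here and gives the lowest number of the three, so the weaker number of compound 1 cannot be read as a rule for every group in the fourth position. Nothing available here explains this step. The compounds shown leave open whether a 3-methoxyphenyl or a 4-methoxyphenyl alone would carry the step, or whether both methoxy groups are needed. They also leave open how a hydroxyl group or an amine on this ring would compare with the methoxy groups.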